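The source may hold more compounds than are shown below. What is called first, only, known or untested is meant among the compounds shown, and "the series" means these compounds.

Among the measured compounds shown here, in a functional assay on CCRF-CEM cells (Homo sapiens) for antiproliferative activity, with a stated time of 72 h (on this read-out higher numbers stand for weaker inhibition and lower numbers for stronger inhibition), compound 3 (`Cc1cccc(CNc2ncnc3c2ncn3[C@@H]2O[C@H](CO)[C@@H](O)[C@H]2O)c1O`) gives 900 nM, the lowest of the three numbers so far. Compound 1 (`OC[C@H]1O[C@@H](n2cnc3c(NCc4cccc(Br)c4)ncnc32)[C@H](O)[C@@H]1O`) gives 5000 nM, and compound 2 (`OC[C@H]1O[C@@H](n2cnc3c(NCc4c(F)ccc(F)c4F)ncnc32)[C@H](O)[C@@H]1O`) gives 90300 nM. Compound 4 (`Cc1ccc(O)c(CNc2ncnc3c2ncn3[C@@H]2O[C@H](CO)[C@@H](O)[C@H]2O)c1`) has yet to be measured. Its difference from compound 3 is 2-hydroxy-5-methylphenyl in place of 2-hydroxy-3-methylphenyl on a saturated chain carbon bound to a nitrogen on an aromatic ring, with the same atoms joined differently.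

For the measured compounds named here, no measured step isolates a change of this kind. Going by the values given here, the steps that bear on it each replace the whole group at this place: an 18-fold higher number from compound 1 to compound 2 (1.26 log units; beyond the scatter) was large, a 5.6-fold lower number from compound 1 to compound 3 (0.74 log units; beyond the scatter) was modest, and a 100-fold lower number from compound 2 to compound 3 (2.00 log units; beyond the scatter) was large. Those swaps exchanged different substituents, whereas the two groups here share their hydroxy and methyl, so a much smaller step is expected, probably none beyond the scatter. The slight lean toward a higher number rests on compound 3 at 900 nM being the lowest so far.

The estimated step is a 1.7-fold higher number from compound 3 to compound 4 (0.22 log units; within the scatter). For compound 4 the estimated value is 1500 nM, with an expected range from 300 nM to 7000 nM.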

Compound 4, half-maximal inhibitory concentration: 1900 nM
Compound 4: middle estimate off by 1.3-fold (0.10 log units), on the low side, and the stated range covers the measured number.
By their numbers in this assay, from the lowest: compound 3; then compound 4; then compound 1; then compound 2.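

Moving the methyl while keeping the hydroxy is the first change at this place that leaves the atoms of the group unchanged, and in this assay the rearrangement alone gives a 2.1-fold higher number from compound 3 to compound 4 (0.32 log units; beyond the scatter) and so is not silent. The 2-hydroxy-5-methylphenyl group also stays ahead of both halogenated groups, with a 2.6-fold lower number from compound 1 to compound 4 (0.42 log units; beyond the scatter) and with a 48-fold lower number from compound 2 to compound 4 (1.68 log units; beyond the scatter) as well, so compound 3 and compound 4 both give lower numbers than compound 1 and compound 2. Nothing available explains why the same atoms joined differently shift the number.

The compounds shown do not separate what the hydroxy contributes from what the methyl contributes. On these data alone, whether a methoxy or an amine in place of the hydroxy, or an ethyl in place of the methyl, would hold the number this low remains open.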